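Amide substituent variation on the shared core: compound 4

This account rests on a few compounds, and the source may have more. Where it says the series, first, only, none or still open, it means among the compounds named here.

Measured so far:
compound 1 `CCn1c(C(=O)NCCN)ccc1C(CC)(CC)c1ccc(OCS(=O)(=O)c2ccccc2)c(C)c1`: 6890 nM
compound 2 `CCn1c(C(=O)N[C@@H](CO)C(C)C)ccc1C(CC)(CC)c1ccc(OCS(=O)(=O)c2ccccc2)c(C)c1`: 10600 nM
compound 3 `CCn1c(C(=O)N[C@H](CO)CCCO)ccc1C(CC)(CC)c1ccc(OCS(=O)(=O)c2ccccc2)c(C)c1`: 6810 nM

All three were measured in a functional assay on PC-3 cells (Homo sapiens) for antiproliferative activity, read by MTT assay, with a stated time of 24 h; on this read-out higher numbers stand for weaker inhibition and lower numbers for stronger inhibition. Compound 1 gives the second highest of the three numbers; its nearest neighbour is compound 3 with a 1.0-fold lower number from compound 1 to compound 3 (0.01 log units; within the scatter), its furthest compound 2 with a 1.5-fold higher number from compound 1 to compound 2 (0.19 log units; within the scatter). The step from compound 2 to compound 3 is likewise a 1.6-fold lower number from compound 2 to compound 3 (0.19 log units; within the scatter). Every variation of the group on the amide-type nitrogen so far has stayed within the scatter.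

Compound 4 `CCn1c(C(=O)N[C@@H](CC(=O)O)C(=O)O)ccc1C(CC)(CC)c1ccc(OCS(=O)(=O)c2ccccc2)c(C)c1` carries 1,2-dicarboxyethyl in place of 2-aminoethyl on an amide-type nitrogen. The steps from compound 1 to compound 2 and to compound 3 bear on this change, and both were within the scatter, so no step beyond the scatter is expected: compound 4 is estimated at 7500 nM (range 3000 nM to 20000 nM), meaning an expected step of a 1.1-fold higher number from compound 1 to compound 4 (0.04 log units; within the scatter).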

Compound 4, half-maximal inhibitory concentration: > 50000 nM
Compound 4 ended at the assay's limit; the forecaster's own chance of this, stated with the estimate: 10%; middle value at least 6.6-fold (0.82 log units) from the limit.
By their numbers in this assay, from the lowest: compounds 3, 1 and 2 (each within the scatter of the next). At a limit, above all of these: compound 4.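

Compound 4 stands at a limit in this assay, not at a number: the limit of > 50000 nM in this assay, at which 1 of the 4 values shown sits.

The group on the amide-type nitrogen can matter after all: with 1,2-dicarboxyethyl the series shows an at least 7.2-fold higher number from compound 1 to compound 4 (0.86 log units; beyond the scatter), an at least 7.3-fold higher number from compound 3 to compound 4 (0.86 log units; beyond the scatter) and an at least 4.7-fold higher number from compound 2 to compound 4 (0.67 log units; beyond the scatter), its first steps beyond the scatter. The tolerance seen among compounds 1, 2 and 3 therefore does not extend to every group at this place.

Going by these compounds, how far compound 4 lies past the limit stays open. So does whether one carboxylic acid, as in carboxymethyl, or an ester of the two acids would give the same step.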